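The source may report more compounds than this note shows. Statements on the series, on what has been measured and on what is new or still open speak of the compounds shown alone.

Of the compounds shown here, two on a shared core have been measured, and a third awaits its turn. Compound 1 `Nc1ncc(-c2ccc(F)cc2)c(-c2ccccc2)n1` is one of them. In an assay on CHO cells for displacement of a labelled ligand from adenosine receptor A1 (Homo sapiens), read by scintillation counting, with a stated time of 1 h, tested at 1 uM (on this read-out lower numbers stand for less inhibition and higher numbers for more inhibition at the one concentration tested (going by the name of the read-out)), compound 1 is reported only at a limit of the assay, > 80%, so no plain number is known for it. That value is the limit of > 80% in this assay, at which 1 of the 2 values shown sits, and nothing more. Compound 2 `Clc1cccc(-c2cnc(Nc3ccccc3)nc2-c2ccccc2)c1` carries an anilino group on the same core. In this assay, within the data shown here, compound 2 gives 34%, the only plain number in the set, and that number is where compound 2 stands. Compound 3 `Clc1cccc(-c2cnc(NCc3ccccc3)nc2-c2ccccc2)c1` has not yet been measured. It differs from compound 2 in one place (benzyl in place of phenyl on a nitrogen on an aromatic ring). Among the measured compounds shown here, no step between measured compounds exists to size this kind of change, so the expectation rests on compound 2 alone. In this assay a small shift is expected, with no firm direction, and probably not beyond the scatter of repeated measurements. Compound 3 is therefore expected to give 40%, in a range from 15% to 70%, which means an estimated step of a number 6 percentage points higher from compound 2 to compound 3 (within the scatter).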

Compound 3, a percentage reported as inhibition, at one concentration (the size of the read-out at that concentration, not a potency): 16%
Estimate against measurement, compound 3: 24 percentage points above; low and high end bracket the measured number.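

Benzyl in place of phenyl on this nitrogen gives, in this assay, a number 18 percentage points lower from compound 2 to compound 3 (beyond the scatter), and this is the first step that sizes any change at this place. It shows that the read-out is sensitive to what sits on this nitrogen, even though the two groups share one six-membered aromatic ring of carbon only, have no hydrogen-bond donors or acceptors and carry no net charge, and differ by 7 heavy atoms against 6. Nothing among the measurements shown explains why this step goes the way it does.

This remains a single step on a single pair of compounds, so it cannot be said whether a longer chain such as phenethyl on the same nitrogen would continue the trend or reverse it. Also open, going by these compounds, is how a simple alkyl group such as methyl, or a saturated ring such as cyclohexyl in place of the aromatic ring, would compare with the anilino and benzylamino groups on the shared core.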